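The compounds below may be only part of what the source reports. "The series", "measured", "known", "first", "only" and "open" are said of these compounds alone.

Measured so far in a functional assay on HeLa cells (Homo sapiens) for inhibition, with a stated time of 72 h; a higher number here means that more compound is needed for the effect, a lower number that less compound is needed: compound 1 `COc1cc(CNCc2ccccc2)ccc1OCc1ccc(Cl)nc1` gives 90000 nM; compound 2 `COc1cc(CNCCSc2nnnn2C)ccc1OCc1ccc(Cl)nc1` gives 86000 nM; compound 3 `COc1cc(CNCc2ccc(C(=O)O)cc2)ccc1OCc1ccc(Cl)nc1` gives "nd(insoluble)" (no result reported), which is no result at all.

Compound 3 therefore stands nowhere on the numbers: it has no value in this assay. Compound 4 `COCCNCc1ccc(OCc2ccc(Cl)nc2)c(OC)c1` differs from it in one place: methoxymethyl in place of 4-carboxyphenyl on a saturated chain carbon bound to an amine nitrogen. Among the measured compounds shown here, the only measured step, a 1.0-fold lower number from compound 1 to compound 2 (0.02 log units; within the scatter), also exchanges a group on a saturated chain carbon bound to an amine nitrogen, and it lies within the scatter. For the measured compounds named here, no step connects compound 3 to any measured compound, so the expectation for compound 4 rests on compound 1 and compound 2 alone, which sit close together, and no shift beyond the scatter is assumed. Compound 4 is expected to give about 90000 nM in this assay, within a range from 30000 nM to 300000 nM.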

Compound 4, half-maximal effective concentration: 97000 nM
For compound 4 the middle estimate is 1.1-fold (0.03 log units) below the measured one; low and high end bracket the measured number.
By their numbers in this assay, from the lowest: compounds 2, 1 and 4 (each within the scatter of the next).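

In this assay, methoxymethyl in place of phenyl gives a 1.1-fold higher number from compound 1 to compound 4 (0.03 log units; within the scatter), and methoxy in place of (1-methyl-1H-tetrazol-5-yl)sulfanyl gives a 1.1-fold higher number from compound 2 to compound 4 (0.05 log units; within the scatter). On a saturated chain carbon bound to an amine nitrogen, a group with no ring therefore reads the same as phenyl, and the three measured compounds are not separated. Nothing measured here accounts for this flat result.

Compound 3 has no value, so 4-carboxyphenyl remains unread. As far as these compounds go, whether a morpholine or a longer chain at this place would move the number beyond the scatter remains open.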